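This account rests on a few compounds, and the source may have more. Where it says the series, first, only, none or still open, it means among the compounds named here.

Measured so far:
Compound 1 `Oc1ccc(O)c(/C=N/c2ccc(OCc3ccccc3)cc2)c1` gives 21300 nM in a functional assay, with a stated time of 30 min; on this read-out higher numbers stand for weaker inhibition and lower numbers for stronger inhibition.
Compound 2 `Oc1ccc(F)cc1/C=N/c1ccc(OCc2ccccc2)cc1` returns only the limit > 200000 nM in this assay.
Compound 3 `Cc1ccc(O)c(/C=N/c2ccc(OCc3ccccc3)cc2)c1` likewise returns only the limit > 200000 nM in this assay.

Compound 3 thus stands at the limit of > 200000 nM in this assay, at which 2 of the 3 values shown sit; only compound 1 returns a number. The steps of an at least 9.3-fold higher number from compound 1 to compound 3 (0.97 log units; beyond the scatter) and an at least 9.3-fold higher number from compound 1 to compound 2 (0.97 log units; beyond the scatter) both show the exchange of the hydroxy of compound 1 for a group without it pushing the read-out past the limit, while the step that the two limits leave unreadable from compound 2 to compound 3 cannot be read. Compound 4 `O=[N+]([O-])c1ccc(O)c(/C=N/c2ccc(OCc3ccccc3)cc2)c1` is the next member, and it differs from compound 3 as nitro in place of methyl on an aromatic carbon. Among the compounds with values here, no measured step exchanges methyl for nitro, so the only guidance is that compound 3 starts at the limit and compound 1 shows what a hydroxy-bearing analogue of the same core reaches. The expected step is an at least 3.3-fold lower number from compound 3 to compound 4 (0.52 log units; beyond the scatter), with wide uncertainty. Compound 4 is estimated at 60000 nM, within 10000 nM to 250000 nM, in this assay, and a limit rather than a number is a real possibility.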

Compound 4, half-maximal inhibitory concentration: > 200000 nM
Compound 4 ended at the assay's limit (the forecaster's own chance of this, stated with the estimate: 45%); at least 3.3-fold (0.52 log units) between middle value and limit.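

In this assay compound 4 gives only a limit, so nitro, which brings hydrogen-bond acceptors and no hydrogen-bond donor, joins fluoro and methyl as a group at this position that yields no number. Nitro in place of hydroxy on this aromatic carbon gives an at least 9.3-fold higher number from compound 1 to compound 4 (0.97 log units; beyond the scatter), a third replacement of the hydroxy of compound 1 that ends past the limit. The steps among compound 2, compound 3 and compound 4 cannot be read, and hydroxy in compound 1 remains the only group at this position with a measured number: the limit of > 200000 nM in this assay, at which 3 of the 4 values shown sit.

Open, going by these compounds, is whether any other group para to the hydroxy group, such as an amine, a methoxy or a carboxylic acid, returns a number. Also open, on these data alone, is how fluoro, methyl and nitro rank against each other, since all three sit at the limit.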